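Methyl for methoxy on the aryl amide of an N-oxide

This account rests on a few compounds, and the source may have more. Where it says the series, first, only, none or still open, it means among the compounds named here.

Of the compounds shown here, three have been measured in a functional assay on HEK293 cells for agonist activity at D(4) dopamine receptor (Homo sapiens), read by FLIPR; on this read-out lower numbers stand for an effect already at smaller amounts and higher numbers for an effect only at larger amounts of compound. Compound 1, `Cc1cccc(C(=O)NCN2CCC(c3nccs3)CC2)c1`, gives 9.8 nM. Compound 3, `COc1cccc(C)c1NC(=O)CN1CCC(c2ccccn2)CC1`, gives 40 nM. Compound 2, `COc1cccc(C)c1NC(=O)CN1CCC(c2cccc[n+]2[O-])CC1`, gives 340 nM, the highest of the three numbers; its nearest neighbour is compound 3, and compound 1 lies furthest from it, as the two values show.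

Going by the values given here, only one step between measured compounds differs in a single place: an 8.5-fold lower number from compound 2 to compound 3 (0.93 log units; beyond the scatter). That step swaps one six-membered aromatic ring on a saturated ring carbon for another and says nothing about the amide-bearing aromatic ring, which is where compound 4, `Cc1cccc(C)c1NC(=O)CN1CCC(c2cccc[n+]2[O-])CC1`, differs from compound 2: methyl in place of methoxy on an aromatic carbon. Among the compounds with values here, no measured pair isolates this change, so there is no step to lean on, and the expectation is that the number in this assay moves little, if at all, beyond the scatter.

Compound 4 is therefore expected to give about 300 nM in this assay, within a range from 120 nM to 800 nM. This estimate corresponds to a step of a 1.1-fold lower number from compound 2 to compound 4 (0.05 log units; within the scatter), which is expected to stay within the scatter.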

Compound 4, half-maximal effective concentration: 346 nM
The estimate for compound 4 lay 1.2-fold (0.06 log units) below the measured number, and the stated range covers the measured number.
By their numbers in this assay, from the lowest: compound 1; then compound 3; then compounds 2 and 4 (each within the scatter of the next).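

In this assay, the methoxy on this aromatic carbon, ortho to a large group, can give way to methyl with no readable effect: the result is a 1.0-fold higher number from compound 2 to compound 4 (0.01 log units; within the scatter). Going by these compounds alone, the only earlier step, an 8.5-fold lower number from compound 2 to compound 3 (0.93 log units; beyond the scatter), changed the six-membered aromatic ring on the saturated ring carbon, so this is the first direct look at the amide-bearing aromatic ring, and here one heavy atom fewer and one hydrogen-bond acceptor fewer leave the number within the scatter. Nothing available explains why this swap leaves the read-out where it is.

Going by these compounds, the pair covers only methoxy and methyl on a single background, so whether the same swap would be equally silent on compound 3, which carries the ring without the N-oxide oxygen, remains open. On these data alone, it also remains open how this position would respond to groups of a different kind, such as an amine, a carboxylic acid or a longer chain like ethoxy, since two similar small groups say little about the range of what fits there.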